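Swapping a methyl for a methoxyethoxy chain on a carbonyl

A few compounds are considered here, and "the series" means these few. Any claim that something is new, unique, unknown or untested is made for them only; others in the source may bear on it.

Measured compounds:
- Compound 1 `O=C(Nc1nc2ccc(N/C(S)=N/c3ccccc3OC(F)(F)F)cc2s1)C1CCCCC1`; in a functional assay on WI-38 VA13 cells (Homo sapiens) for cytotoxicity (on this read-out lower numbers stand for an effect already at smaller amounts and higher numbers for an effect only at larger amounts of compound), compound 1 gives 2.3 ug/mL.
- Compound 2 `CC(=O)Nc1nc2ccc(NC(=O)c3c(Cl)cccc3Cl)cc2s1`; in this assay compound 2 gives 0.6 ug/mL.

Of the two measured compounds, compound 2 stands at the lower number, meaning it affects the cells already at the smaller amount; the gap between compound 1 and compound 2 lies beyond the usual scatter of repeated measurements. Compound 3 `COCCOC(=O)Nc1nc2ccc(NC(=O)c3c(Cl)cccc3Cl)cc2s1` has not yet been measured. It differs from compound 2 in one place only: 2-methoxyethoxy in place of methyl on a carbonyl carbon. The exchange sits on a carbonyl carbon whose other neighbour is an amide-type nitrogen, and everything else in compound 2 is kept unchanged. No measured pair shows this particular change on its own, so there is no shown step to lean on, and a small move in either direction or none beyond the scatter remains open. On balance a modest shift toward a higher number is judged slightly more likely than a shift toward a lower one. The step from compound 2 to compound 3 is estimated as a 1.7-fold higher number from compound 2 to compound 3 (0.22 log units; within the scatter). Compound 3 is expected to give about 1 ug/mL, within a range from 0.3 ug/mL to 3.5 ug/mL.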

Compound 3, half-maximal effective concentration: 0.011 ug/mL
Beside the measured number, compound 3's estimate is 91-fold (1.96 log units) above it, outside the stated range (below it).
By their numbers in this assay, from the lowest: compound 3; then compound 2; then compound 1.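

In this assay, the group on this carbonyl carbon turns out to matter a great deal: putting 2-methoxyethoxy in place of methyl gives a 55-fold lower number from compound 2 to compound 3 (1.74 log units; beyond the scatter), while the rest of the molecule stays the same. This position, on a carbonyl carbon whose other neighbour is an amide-type nitrogen, therefore tolerates a larger chain, and with that chain the effect on the cells appears at a much smaller amount of compound. No measurement at hand bears on why the number moves this far.

The single exchange alters two things at once, adding an oxygen directly on the carbonyl carbon and adding the rest of the chain, and the compounds shown do not tell which of these carries the step. A plain methoxy on the same carbonyl carbon would separate the two parts, while a longer chain, or a chain ending in an amine or a carboxylic acid, would show whether the low number holds when the far end of the group changes.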